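Swapping the aryl group on the hydrazone carbon

The compounds below may be only part of what the source reports. "The series", "measured", "known", "first", "only" and "open" are said of these compounds alone.

Going by the values given here, compound 2 `Nc1nc(N/N=C/c2ccc[nH]2)nc2c1ncn2[C@@H]1O[C@H](CO)[C@@H](O)[C@H]1O` gives 8 nM in an assay on CHO-K1 cells for displacement of a labelled ligand from adenosine receptor A1 (Homo sapiens), read by scintillation counting, with a stated time of 60 min (on this read-out lower numbers stand for stronger inhibition and higher numbers for weaker inhibition), the highest of the two numbers measured so far. Its nearest neighbour is compound 1 `Nc1nc(N/N=C/c2cccnc2Cl)nc2c1ncn2[C@@H]1O[C@H](CO)[C@@H](O)[C@H]1O`, which gives 4.6 nM; a 1.7-fold higher number from compound 1 to compound 2 (0.24 log units; within the scatter). Compound 3 `CN(C)c1ccc(/C=N/Nc2nc(N)c3ncn([C@@H]4O[C@H](CO)[C@@H](O)[C@H]4O)c3n2)cc1` has not yet been measured. It differs from compound 2 by 4-(dimethylamino)phenyl in place of 1H-pyrrol-2-yl on a carbon with a double bond to nitrogen. Among the compounds with values here, the only measured step also exchanged the group on this same carbon with a double bond to nitrogen and stayed within the scatter, so no step beyond the scatter is expected in this assay: a 1.3-fold higher number from compound 2 to compound 3 (0.10 log units; within the scatter). Compound 3 is estimated at 10 nM, with a range from 3 nM to 35 nM.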

Compound 3, inhibition constant: > 10000 nM
Compound 3 ended at the assay's limit; the forecaster's own chance of this, stated with the estimate: 3%; at least 1000-fold (3.00 log units) between middle value and limit.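

This carbon with a double bond to nitrogen tolerates less than the two earlier compounds suggested: in this assay, the exchange to 4-(dimethylamino)phenyl brings an at least 1200-fold higher number from compound 2 to compound 3 (3.09 log units; beyond the scatter) and an at least 2100-fold higher number from compound 1 to compound 3 (3.33 log units; beyond the scatter). Both steps are large, whereas 1H-pyrrol-2-yl and 2-chloropyridin-3-yl stayed within the scatter of each other. The value of compound 3 is a limit of the assay, not a number: the limit of > 10000 nM in this assay, at which 1 of the 3 values shown sits.

The dimethylamino group and the phenyl ring enter together, and the compounds shown do not tell which of them carries the loss. An unsubstituted phenyl or a 4-methoxyphenyl group on this carbon would separate the two.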